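A few compounds are considered here, and "the series" means these few. Any claim that something is new, unique, unknown or untested is made for them only; others in the source may bear on it.

Compound 2 `CCOC(=O)C1=C(C)NC(C)=C(C(=O)OCC)C1c1ccc(OCC(=O)NNC(=O)c2ccccc2)cc1` gives 44.5% in a functional assay on the whole organism (strain Wistar) for inhibition, with Rattus norvegicus as the target, read by paw edema, with stated times of 30 min and 2 h, at a dose of 20 mg/kg; on this read-out higher numbers stand for more inhibition at the one dose given (going by the name of the read-out) and lower numbers for less inhibition. Among the two compounds measured so far it has the lowest number, yet compound 1 `CCOC(=O)C1=C(C)NC(C)=C(C(=O)OCC)C1c1ccc(OCC(=O)Nc2c(C)cccc2C)cc1`, with 47.8% in this assay, lies within the scatter of it, so no order between the two can be claimed. Compound 3 `CCOC(=O)C1=C(C)NC(C)=C(C(=O)OCC)C1c1ccc(OCC(=O)n2nc(C)cc2C)cc1` has not yet been measured. It differs from compound 2 in one place: 3,5-dimethyl-1H-pyrazol-1-yl in place of benzamidoamino on a carbonyl carbon. Among the compounds with values here, only one measured step speaks to such a change at the end of the chain bearing the carbonyl: the exchange a number 3.3 percentage points lower from compound 1 to compound 2 (within the scatter), which stayed within the scatter. On that basis no step beyond the scatter is expected in this assay, in either direction, and the estimated step of a number 0.5 percentage points higher from compound 2 to compound 3 (within the scatter) is small. Compound 3 is therefore expected to give about 45% in this assay, most likely between 30% and 60%.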

Compound 3, a percentage reported as inhibition, in the whole organism at one dose (the size of the read-out at that dose, not a potency): 46.1%
Compound 3: middle estimate off by 1.1 percentage points, on the low side, within the range that was stated.
By their numbers in this assay, from the lowest: compounds 2, 3 and 1 (each within the scatter of the next).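

In this assay the carbonyl carbon now carries 3,5-dimethyl-1H-pyrazol-1-yl, a group with no hydrogen-bond donors, and the change stays small (a number 1.6 percentage points higher from compound 2 to compound 3 (within the scatter)) when set against benzamidoamino and also against (2,6-dimethylphenyl)amino (a number 1.7 percentage points lower from compound 1 to compound 3 (within the scatter)). At this place, then, three groups that differ in ring type, ring size and hydrogen-bond donors give numbers that cannot be told apart, so neither the six-membered aromatic ring nor the amide-type hydrogen of the earlier groups shows up as needed among these compounds. Nothing available explains this lack of a difference.

Still open, on these data alone, is whether any group on this carbonyl carbon can move the number beyond the scatter, a hydroxyl giving the carboxylic acid or a morpholine for instance. The compounds shown also leave open what a longer chain before that carbonyl would do.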